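Dropping the Methoxymethoxy Group from Compound 1

The compounds below may be only part of what the source reports. "The series", "measured", "known", "first", "only" and "open" are said of these compounds alone.

Measured compounds:
compound 1 `COCOc1cc(C2=C(c3cc(OC)c(OC)c(OC)c3)C(=O)CC2O[SiH2]C(C)(C)C)ccc1OC` — 34 ug/mL
compound 2 `O/N=C1/CC(O)C(c2ccccc2)=C1c1ccccc1` — > 100 ug/mL

Within the data shown here, in an ADME assay on DU-145 cells (Homo sapiens) for cytotoxicity, read by MTT assay, with a stated time of 72 h (on this read-out higher numbers stand for weaker inhibition and lower numbers for stronger inhibition), compound 1 gives 34 ug/mL, the only actual number among the two values shown. Compound 2 reaches only (the limit of > 100 ug/mL in this assay, at which 1 of the 2 values shown sits), which is a limit of the assay and not a number. Compound 3 `COc1ccc(C2=C(c3cc(OC)c(OC)c(OC)c3)C(=O)CC2O[SiH2]C(C)(C)C)cc1` has not yet been measured. Among the measured compounds shown here, it differs from compound 1 in one place: hydrogen in place of methoxymethoxy on an aromatic carbon The two measured compounds differ in many places at once, so no single step between them has been set out, and the values show no more than what each compound gives on its own. For the measured compounds named here, with no measured step matching this change, the move from compound 1 to compound 3 is expected to be small, within the usual scatter or leaning a little towards weaker inhibition. Compound 3 is expected to give about 45 ug/mL, with a range from 15 ug/mL to 100 ug/mL. This amounts to an expected step of a 1.3-fold higher number from compound 1 to compound 3 (0.12 log units; within the scatter).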

Compound 3, half-maximal inhibitory concentration: > 100 ug/mL
Compound 3: no number, only a limit; the forecaster's own chance of this, stated with the estimate: 20%; at least 2.2-fold (0.34 log units) between middle value and limit.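

Among these compounds, this is the first step that changes one place only, and it shows that this position is not indifferent. On an aromatic carbon ortho to a methoxy group, going from methoxymethoxy to hydrogen, that is from 4-methoxy-3-(methoxymethoxy)phenyl to 4-methoxyphenyl, gives an at least 2.9-fold higher number from compound 1 to compound 3 (0.46 log units; beyond the scatter) in this assay. Compound 3 gives > 100 ug/mL, which is a limit of the assay and not a number, so the step has a lower bound only, and the read-out offers little room on this side: the limit of > 100 ug/mL in this assay, at which 2 of the 3 values shown sit.

The compounds shown leave open how far compound 3 lies past that limit. They also leave open whether a hydroxy group, a methoxy group or an ethoxy group on this carbon would match compound 1 or whether the full methoxymethoxy group is needed.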